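From Hydroxyethyl Amide to Methyl Ester on a Shared Core

A few compounds are considered here, and "the series" means these few. Any claim that something is new, unique, unknown or untested is made for them only; others in the source may bear on it.

Compound 1 `O=C(NCCO)c1ccc2ccc(C(=O)c3ccccc3)c-2cc1`: 2.3
Compound 2 `CN(C)C(=O)c1cn(C)c2ccccc12`: 1.8
Compound 3 `O=C(Cn1ccccc1=O)Nc1cc2ccccc2[nH]1`: 1

Of the compounds shown here, three have been measured in a physicochemical assay for lipophilicity, read by HPLC, measured as octanol-water partition, at pH 2; on this read-out higher numbers stand for higher lipophilicity and lower numbers for lower lipophilicity. Compound 1 stands highest of the three: compound 2 lies lower by a margin beyond the usual scatter, and compound 3 lies lower still, also beyond it. Compound 4 `COC(=O)c1ccc2ccc(C(=O)c3ccccc3)c-2cc1` shares the core of compound 1 and differs from it in a single place: methoxy in place of (2-hydroxyethyl)amino on a carbonyl carbon. Among the compounds with values here, no pair of measured compounds isolates this change, so nothing measured here shows its size directly. In this assay the step is nevertheless expected to run upward and to exceed the scatter: a number 1.00 log units higher from compound 1 to compound 4 (beyond the scatter). Compound 4 is accordingly estimated at 3.3, with a range from 2.8 to 3.8.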

Compound 4, distribution coefficient: 4.8
Compound 4: the middle estimate sits 1.50 log units below what was measured; the whole stated range lies below it.
By their numbers in this assay, from the lowest: compound 3; then compound 2; then compound 1; then compound 4.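

In this assay, within the data shown here, methoxy in place of (2-hydroxyethyl)amino on a carbonyl carbon gives a number 2.50 log units higher from compound 1 to compound 4 (beyond the scatter), the first direct reading of this change on the shared core. The entering methoxy carries no hydrogen-bond donors and has fewer heavy atoms than the group it replaces, and the step shows that this single change can move the read-out strongly. No measurement on hand explains the size of the step.

The compounds shown leave open how ethylamino or methylamino on the same carbonyl carbon would read in this assay, so the step cannot yet be divided between the amide nitrogen and the terminal hydroxyl. From the compounds shown here alone, a carboxylic acid at this place also remains open.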